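This account rests on a few compounds, and the source may have more. Where it says the series, first, only, none or still open, it means among the compounds named here.

Measured compounds:
Compound 1 `COc1cc(-c2nccn2C)cc(OC)c1OC`: > 100000 nM
Compound 2 `CCn1ccnc1-c1cc(OC)c(OC)c(OC)c1`: > 100000 nM
Compound 3 `CCCn1ccnc1-c1cc(OC)c(OC)c(OC)c1`: > 100000 nM

In a functional assay on MDA-MB-468 cells (Homo sapiens) for antiproliferative activity, read by MTT assay, with a stated time of 72 h (on this read-out higher numbers stand for weaker inhibition and lower numbers for stronger inhibition), compound 3 gives > 100000 nM, which is a limit of the assay and not a number. All the readings share it: the limit of > 100000 nM in this assay, at which 3 of the 3 values shown sit. Compound 4 `COc1cc(-c2nccn2C(C)C)cc(OC)c1OC` carries isopropyl in place of propyl on an aromatic nitrogen, with the same atoms joined differently. The measured changes on this chain are a step that the two limits leave unreadable from compound 1 to compound 2, a step that the two limits leave unreadable from compound 1 to compound 3 and a step that the two limits leave unreadable from compound 2 to compound 3, and none has a size to carry over. No step beyond the scatter is therefore expected in this assay, and compound 4 will probably report only a limit too. The expected change is a number no higher from compound 3 to compound 4 (the limit leaves the size open). Compound 4 is estimated at 100000 nM, with an expected range of 40000 nM to 200000 nM.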

Compound 4, half-maximal inhibitory concentration: > 100000 nM
Compound 4: a limit, no number (the forecaster's own chance of this, stated with the estimate: 85%); the middle value lies on the limit itself.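

In this assay compound 4 gives > 100000 nM, a limit of the assay and not a number. Its steps from compound 1, compound 2 and compound 3 therefore cannot be read. The compounds shown leave open whether the chain on the aromatic nitrogen alters inhibition at all, because every reading rests on one limit: the limit of > 100000 nM in this assay, at which 4 of the 4 values shown sit.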